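Alpha-substituent change in a TRPV1 antagonist amide series

This account rests on a few compounds, and the source may have more. Where it says the series, first, only, none or still open, it means among the compounds named here.

Measured so far:
compound 1 `CS(=O)(=O)Nc1ccc(C(C(=O)NCc2ccc(C(F)(F)F)nc2SC2CCCCC2)C2CCCC2)cc1F`: 103 nM
compound 2 `CC1CCN(c2nc(C(F)(F)F)ccc2CNC(=O)C(c2ccccc2)c2ccc(NS(C)(=O)=O)c(F)c2)CC1`: 1.3 nM

In an assay on CHO cells for antagonist activity at transient receptor potential cation channel subfamily V member 1 (Homo sapiens), read by FLIPR (a lower number here means a stronger inhibitor, a higher number a weaker inhibitor), compound 2 gives 1.3 nM, the lowest of the two numbers; compound 1 gives 103 nM, a far higher number, beyond the scatter. Compound 3 `CC1CCN(c2nc(C(F)(F)F)ccc2CNC(=O)C(Cc2ccc(F)cc2)c2ccc(NS(C)(=O)=O)c(F)c2)CC1` is not yet measured in this assay. It differs from compound 2 by 4-fluorobenzyl in place of phenyl on a saturated chain carbon bound to an aromatic carbon and a carbonyl carbon. For the measured compounds named here, no measured pair shows this change, so its effect is unknown. A modest weakening is expected, the step of a 3.1-fold higher number from compound 2 to compound 3 (0.49 log units; beyond the scatter), though a result within the scatter would not surprise. Compound 3 is estimated at 4 nM, range 1 nM to 20 nM.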

Compound 3, inhibition constant: 49.3 nM
Estimate against measurement, compound 3: 12-fold (1.09 log units) below, and the stated range ends below it.
By their numbers in this assay, from the lowest: compound 2; then compound 3; then compound 1.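

On the saturated chain carbon bound to an aromatic carbon and a carbonyl carbon, the substituent strongly affects the result: in this assay, 4-fluorobenzyl in place of phenyl gives a 38-fold higher number from compound 2 to compound 3 (1.58 log units; beyond the scatter). On this shared core, phenyl therefore gives the stronger inhibitor of the two groups. Nothing available accounts for the size of this step.

From the compounds shown here alone, it remains open whether the step follows the fluorine or the extra carbon of the 4-fluorobenzyl group. Benzyl and 4-fluorophenyl at this place would separate the two.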